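Aryl variation on a bis-benzylidene diketopiperazine series

This account rests on a few compounds, and the source may have more. Where it says the series, first, only, none or still open, it means among the compounds named here.

Compound 1 `C=CCn1c(=O)/c(=C\c2cc(F)ccc2C)[nH]c(=O)/c1=C\c1ccccc1OC` carries 5-fluoro-2-methylphenyl on one benzylidene arm. Among the compounds with values here, in a functional assay on MOLT-4 cells (Homo sapiens) for cytotoxicity, read by CCK-8 assay, with a stated time of 72 h (a lower number here means a stronger inhibitor, a higher number a weaker inhibitor), compound 1 gives 3800 nM, the only number recorded. Compound 2 `COc1ccccc1/C=c1/[nH]c(=O)/c(=C\c2cccc(Cl)c2Cl)[nH]c1=O` lacks the allyl group on the shared core; in this assay compound 2 gives "not determined" (no result reported). Compound 3 `C=CCn1c(=O)/c(=C\c2cc(Br)ccc2F)[nH]c(=O)/c1=C\c1ccccc1OC` differs from compound 1 by 5-bromo-2-fluorophenyl in place of 5-fluoro-2-methylphenyl on a double-bonded chain carbon bound to an aromatic carbon. Within the data shown here, no comparison between measured compounds covers this change, so a step is expected only of modest size, with no direction clear beyond the scatter: a 1.2-fold lower number from compound 1 to compound 3 (0.07 log units; within the scatter). For compound 3 in this assay the estimate is 3200 nM, ranging from 1100 nM to 9500 nM.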

Compound 3, half-maximal inhibitory concentration: 12900 nM
For compound 3 the middle estimate is 4.0-fold (0.61 log units) below the measured one; measured number outside the range, above it.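

In this assay replacing 5-fluoro-2-methylphenyl with 5-bromo-2-fluorophenyl on a double-bonded chain carbon bound to an aromatic carbon gives a 3.4-fold higher number from compound 1 to compound 3 (0.53 log units; beyond the scatter) and so moves toward weaker inhibition. This shows that the series responds to a change of aryl substituents on this arm. Nothing available bears on the reason for this step.

Which part of the exchange carries the step remains open, as does the outcome with an amine or a carboxylic acid on this arm. The contribution of the allyl group also stays unresolved, since compound 2 has no number.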